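Replacing 2-chlorophenyl with 3,4-dichlorophenyl

The source may report more compounds than this note shows. Statements on the series, on what has been measured and on what is new or still open speak of the compounds shown alone.

Within the data shown here, in a functional assay on HepG2 cells (Homo sapiens) for antiproliferative activity, read by MTT assay, with a stated time of 72 h (a higher number here means a weaker inhibitor, a lower number a stronger inhibitor), compound 1 `NC1=NC2(CCOCC2)N(OCCCOc2ccccc2Cl)C(N)=N1` gives 1750 nM as the only actual number so far. Compound 2 `NC1=NC2(CCSCC2)N(OCCCOc2cc(Cl)c(Cl)cc2Cl)C(N)=N1` stands at > 100000 nM in this assay and this value is a limit of the assay. Among the measured compounds shown here, compound 3 `NC1=NC2(CCOCC2)N(OCCCOc2ccc(Cl)c(Cl)c2)C(N)=N1` keeps the core of compound 1 and carries 3,4-dichlorophenyl in place of 2-chlorophenyl on an oxygen on a saturated carbon as its single change. For the measured compounds named here, no measured pair isolates a change of this kind, so the size of the step in this assay rests on judgement alone. A small shift toward weaker inhibition is expected, perhaps none beyond the scatter. The estimated 1.4-fold higher number from compound 1 to compound 3 (0.15 log units; within the scatter) stays modest on that view. Compound 3 is estimated at 2500 nM with an expected range of 500 nM to 20000 nM in this assay for now.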

Compound 3, half-maximal inhibitory concentration: 380 nM
Beside the measured number, compound 3's estimate is 6.6-fold (0.82 log units) above it, and the stated range ends above it.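

In this assay, the group on an oxygen on a saturated carbon proves able to move the read-out: with the core of compound 1 held constant, 3,4-dichlorophenyl in place of 2-chlorophenyl gives a 4.6-fold lower number from compound 1 to compound 3 (0.66 log units; beyond the scatter). Among these compounds, this is the first step that isolates a single change, and it lies beyond the scatter. The values shown give no cause for the step, and this single pair cannot separate the added chlorine from the altered chlorine pattern.

Compound 2 stands at > 100000 nM, which is a limit of the assay, and it differs from compound 1 and compound 3 in more than one place. Still open, on these data alone, is how an amine, a carboxylic acid or a methoxy group on the phenyl ring, or a longer chain to the oxygen, would read in this assay.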